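Methyl on a Ring Nitrogen: Does Cytotoxicity Shift?

This account rests on a few compounds, and the source may have more. Where it says the series, first, only, none or still open, it means among the compounds named here.

Compound 1 `Cc1cc(O)c(C(c2cn([C@H]3C[C@H](O)[C@@H](CO)O3)c(=O)[nH]c2=O)c2c(O)cc(C)oc2=O)c(=O)o1` was tested in an ADME assay on HEL cells (Homo sapiens) for cytotoxicity, read by microscopy; on this read-out higher numbers stand for lower toxicity in this test and lower numbers for higher toxicity in this test. In this assay compound 1 gives only a limit, > 100000 nM. Compound 2 `Cc1cc2c(c(=O)[nH]1)C(c1cn([C@H]3C[C@H](O)[C@@H](CO)O3)c(=O)[nH]c1=O)C(C#N)=C(N)O2` also gives only a limit in this assay, > 100000 nM. Compound 2 therefore sits at the limit of > 100000 nM in this assay, at which 2 of the 2 values shown sit, with no measured number to set it apart. Compound 3 `Cc1cc2c(c(=O)n1C)C(c1cn([C@H]3C[C@H](O)[C@@H](CO)O3)c(=O)[nH]c1=O)C(C#N)=C(N)O2` differs from compound 2 by one change: methyl in place of hydrogen on an aromatic nitrogen. For the measured compounds named here, no measured step of this kind exists here, so the expected step of a number no higher from compound 2 to compound 3 (the limit leaves the size open) is none beyond the usual scatter. Compound 3 is estimated at 100000 nM, between 30000 nM and 300000 nM.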

Compound 3, minimum cytotoxic concentration: > 100000 nM
Compound 3: no number, only a limit (the forecaster's own chance of this, stated with the estimate: 85%); the middle value lies on the limit itself.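

No step can be read from compound 2 to compound 3, because each gives only a limit: the limit of > 100000 nM in this assay, at which 3 of the 3 values shown sit.

What methyl in place of hydrogen on an aromatic nitrogen does in this assay stays open: none of the compounds shown has a measured number.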